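A few compounds are considered here, and "the series" means these few. Any claim that something is new, unique, unknown or untested is made for them only; others in the source may bear on it.

The series shares one core, shown in compound 1 `C/N=C(\S)n1nc(-c2ccc(C)cc2)nc1N`, whose aryl ring carries a methyl group; compound 2 `C/N=C(\S)n1nc(-c2ccc(N)cc2)nc1N` carries an amino group in its place, and compound 3 `C/N=C(\S)n1nc(-c2ccc(F)cc2)nc1N` a fluoro group. In a functional assay on the whole organism for inhibition, with Rattus norvegicus as the target, at a dose of 30 mg/kg (on this read-out higher numbers stand for more inhibition at the one dose given (going by the name of the read-out) and lower numbers for less inhibition), compound 1 gives 65%, while compound 2 has no result reported. In this assay compound 3 gives 73%. Among the measured compounds shown here, the one step that joins two measured compounds, fluoro in place of methyl on an aromatic carbon, is a number 8 percentage points higher from compound 1 to compound 3 (within the scatter), so the two numbers lie within the scatter of each other and no order can be read between compound 1 and compound 3.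

Compound 4 `C/N=C(\S)n1nc(-c2ccc(C(F)(F)F)cc2)nc1N` differs from compound 3 by trifluoromethyl in place of fluoro on an aromatic carbon. For the measured compounds named here, no measured pair shows a trifluoromethyl group, so the only guide is the step between compound 1 and compound 3, which stayed within the scatter when the group on that aromatic carbon was exchanged. Compound 4 is therefore expected to give 70% in this assay, with a likely range from 50% to 88%. The estimated step is a number 3 percentage points lower from compound 3 to compound 4 (within the scatter), a change not expected to exceed the scatter.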

Compound 4, a percentage reported as inhibition, in the whole organism at one dose (the size of the read-out at that dose, not a potency): 91%
For compound 4 the middle estimate is 21 percentage points below the measured one; measured number outside the range, above it.
By their numbers in this assay, from the lowest: compounds 1 and 3 (each within the scatter of the next); then compound 4.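

The result shows that this aromatic carbon, para to a large group, is not indifferent to what it carries in this assay: the exchange of methyl for fluoro stayed within the scatter, but trifluoromethyl in place of fluoro is a number 18 percentage points higher from compound 3 to compound 4 (beyond the scatter), and trifluoromethyl in place of methyl is a number 26 percentage points higher from compound 1 to compound 4 (beyond the scatter). Among the compounds shown here, since both steps lie beyond the scatter, compound 4 stands above the two other compounds with a number, and trifluoromethyl is the first group to separate itself on this read-out. Nothing available here accounts for the gain, so the data show only that it occurs, not how it arises.

On these data alone, what a chloro group, a nitrile or a trifluoromethoxy group would give at this same carbon stays open, as does the place of the amino group of compound 2, for which no number is available to compare. As far as these compounds go, with a single dose behind each number, it also stays open whether compound 4 would keep its lead at other doses, or whether trifluoromethyl would give a similar step if another part of the shared core were changed.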